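The source may hold more compounds than are shown below. What is called first, only, known or untested is meant among the compounds shown, and "the series" means these compounds.

The measured compounds in a functional assay on PC-3 cells (Homo sapiens) for antiproliferative activity, read by MTT assay, with a stated time of 72 h (a lower number here means a stronger inhibitor, a higher number a weaker inhibitor), are these:

compound 1, `C=CC(=O)Nc1cc2c(N3CCc4ccccc43)ncnc2cc1OC`, which gives 5940 nM;
compound 2, `C=CC(=O)Nc1cc2c(N3CCc4ccccc43)ncnc2cc1O[C@@H]1CCOC1`, which gives 2710 nM;
compound 3, `C/C=C/C(=O)Nc1cc2c(N3CCCc4ccccc43)ncnc2cc1OC`, which gives 7520 nM.

Compound 2 gives the lowest number of the three. Within the data shown here, its nearest neighbour is compound 1: the single measured step, a 2.2-fold lower number from compound 1 to compound 2 (0.34 log units; beyond the scatter), is a modest one and lies beyond the scatter. Among the measured compounds shown here, compound 3 is the furthest from compound 2; no single step links the two, since compound 3 differs from compound 2 in more than one place, and its value in this assay simply stands higher than that of compound 2.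

Compound 4, `CCN(CC)C/C=C/C(=O)Nc1cc2c(N3CCc4ccccc43)ncnc2cc1O[C@@H]1CCOC1`, is the next compound on this path. Its change from compound 2 is 3-(diethylamino)prop-1-en-1-yl in place of vinyl on a carbonyl carbon. For the measured compounds named here, no measured step bears on this change: the one step on record, from compound 1 to compound 2, alters the group on the oxygen on the aromatic ring, not the carbonyl carbon, and compound 3 reaches its different group on the carbonyl carbon together with a second change. The account therefore expects no step beyond the scatter in this assay, and the estimated step is a 1.4-fold lower number from compound 2 to compound 4 (0.13 log units; within the scatter). Compound 4 is estimated at 2000 nM, with a range from 700 nM to 6000 nM.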

Compound 4, half-maximal inhibitory concentration: 5780 nM
Compound 4: middle estimate off by 2.9-fold (0.46 log units), on the low side, and the stated range covers the measured number.
By their numbers in this assay, from the lowest: compound 2; then compounds 4, 1 and 3 (each within the scatter of the next).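

In this assay the carbonyl carbon whose other neighbour is the amide-type nitrogen can now be read with nothing else altered, and 3-(diethylamino)prop-1-en-1-yl in place of vinyl gives a 2.1-fold higher number from compound 2 to compound 4 (0.33 log units; beyond the scatter) as a modest step beyond the scatter. Among these compounds, the earlier step concerned only the group on the oxygen on the aromatic ring, so this is the first sign that the number also responds to the group on the carbonyl carbon, and here the larger group, which brings a nitrogen and a hydrogen-bond acceptor, goes with the higher number. No measurement at hand explains why the number moves in this direction.

As far as these compounds go, it remains open whether the step belongs to the diethylamino end or to the longer chain itself, a question that a morpholine or a piperidine in its place, or a chain carrying no amine, could address. From the compounds shown here alone, the step is also read only with the oxolan-3-yl group of compound 2, so its size with the methyl on the oxygen, as in compound 1, remains unknown.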